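A few compounds are considered here, and "the series" means these few. Any claim that something is new, unique, unknown or untested is made for them only; others in the source may bear on it.

Compound 2 `Cn1c(-c2ccccc2)nc2c(Sc3ccccc3)ncnc21` gives 42% in an assay on isolated protein for inhibition of RAC-alpha serine/threonine-protein kinase (Homo sapiens), tested at 30 uM (on this read-out lower numbers stand for less inhibition and higher numbers for more inhibition at the one concentration tested (going by the name of the read-out)), the highest of the three numbers measured; compound 1 `Cn1cnc2c(Sc3ccccc3)ncnc21` gives 0% and compound 3 `Cn1c(-c2ccc([S+](C)[O-])cc2)nc2c(Sc3ccccc3)ncnc21` gives 4%. The step of a number 42 percentage points higher from compound 1 to compound 2 (beyond the scatter) shows that the phenyl on the core carries the inhibition, while a number 38 percentage points lower from compound 2 to compound 3 (beyond the scatter) shows that a substituent on that phenyl removes most of it again.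

Compound 4 `Cn1c(Br)nc2c(Sc3ccccc3)ncnc21` differs from compound 2 as follows: bromo in place of phenyl on an aromatic carbon. The step that bears on this is a number 42 percentage points higher from compound 1 to compound 2 (beyond the scatter), since bromo, like hydrogen, is a single atom in that place and not a ring. A large drop in this assay is therefore expected, a number 32 percentage points lower from compound 2 to compound 4 (beyond the scatter), back toward the number of compound 1. Compound 4 is estimated at 10%, within 0% to 30%.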

Compound 4, a percentage reported as inhibition, at one concentration (the size of the read-out at that concentration, not a potency): 1%
Estimate against measurement, compound 4: 9 percentage points above; low and high end bracket the measured number.
By their numbers in this assay, from the lowest: compounds 1, 4 and 3 (each within the scatter of the next); then compound 2.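

At the aromatic carbon between two ring nitrogen atoms, bromo does not stand in for phenyl in this assay: the change gives a number 41 percentage points lower from compound 2 to compound 4 (beyond the scatter). Set against hydrogen, bromo gives a number 1 percentage points higher from compound 1 to compound 4 (within the scatter), so neither of these two non-ring groups carries the inhibition seen with phenyl. No measurement shown here accounts for this difference.

Open, on these data alone, is whether a ring other than phenyl, such as pyridyl or cyclohexyl, keeps the inhibition at this carbon. Also open, as far as these compounds go, is whether a non-ring group larger than bromo, such as an amine or a longer alkyl chain, does the same.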